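The compounds below may be only part of what the source reports. "The series", "measured", "known", "first", "only" and "open" are said of these compounds alone.

In an assay on isolated protein for inhibition of ubiquitin carboxyl-terminal hydrolase 7 (Homo sapiens), with stated times of 30 min and 2 h (on this read-out higher numbers stand for weaker inhibition and lower numbers for stronger inhibition), three compounds have been measured. Compound 1 `Cn1nc2c(=O)n(CC3(O)CCN(Cc4ccc(-c5cccs5)cc4Cl)CC3)cnc2c1-c1ccc(CN)cc1` gives 38.6 nM, compound 2 `Cn1nc2c(=O)n(CC3(O)CCN(Cc4ccc(-c5ccco5)cc4Cl)CC3)cnc2c1-c1ccc(C(N)=O)cc1` gives 80.8 nM, and compound 3 `Cn1nc2c(=O)n(CC3(O)CCN(Cc4ccc(-c5ccncc5)cc4Cl)CC3)cnc2c1-c1ccc(CN)cc1` gives 257 nM. Compound 3 therefore stands highest of the three numbers, and its distance to compound 2 and to compound 1 lies beyond the scatter in each case, so compound 3 is the weakest inhibitor among them.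

Compound 4 `Cn1nc2c(=O)n(CC3(O)CCN(Cc4ccc(-c5ccsc5)cc4Cl)CC3)cnc2c1-c1ccc(CN)cc1` differs from compound 3 in one place: thiophen-3-yl in place of pyridin-4-yl on an aromatic carbon.

For the measured compounds named here, one measured step bears on this change. The step of a 6.7-fold higher number from compound 1 to compound 3 (0.82 log units; beyond the scatter) shows that putting pyridin-4-yl in place of thiophen-2-yl raised the number by a modest, clearly resolved amount. The change from compound 3 to compound 4 runs the other way, exchanging pyridin-4-yl for a thiophene, though here thiophen-3-yl rather than thiophen-2-yl, so the number is expected to come back down by a step of similar size.

Compound 4 is thus estimated at 50 nM, within a range from 20 nM to 130 nM, a step of a 5.1-fold lower number from compound 3 to compound 4 (0.71 log units; beyond the scatter) that is expected to lie beyond the scatter.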

Compound 4, half-maximal inhibitory concentration: 59.5 nM
For compound 4 the middle estimate is 1.2-fold (0.08 log units) below the measured one, within the range that was stated.
By their numbers in this assay, from the lowest: compounds 1, 4 and 2 (each within the scatter of the next, the first and the last beyond it); then compound 3.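

On the aromatic carbon para to a large group, thiophen-3-yl recovers most of what pyridin-4-yl gave up, with a 4.3-fold lower number from compound 3 to compound 4 (0.64 log units; beyond the scatter), so inhibition is clearly stronger with this thiophene. The point at which the thiophene is attached matters little here: a 1.5-fold higher number from compound 1 to compound 4 (0.19 log units; within the scatter) means that thiophen-2-yl and thiophen-3-yl cannot be told apart at this position. Nothing available here explains why pyridin-4-yl gives weaker inhibition than either thiophene.

On these data alone, it remains open whether the weaker inhibition goes with the six-membered ring or with its ring nitrogen, and a plain phenyl ring in this place would separate the two. Also open, as far as these compounds go, is how a non-aromatic group, such as a dimethylamino group, would compare with thiophen-3-yl here.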